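Hydrazone Acylhydrazides: From Aminophenyl to Thiophene

The source may report more compounds than this note shows. Statements on the series, on what has been measured and on what is new or still open speak of the compounds shown alone.

Measured compounds:
compound 1 `C/C(=N\NC(=O)c1ccc(C(F)(F)F)cc1)c1cnccn1`, 1160 nM
compound 2 `Nc1ccc(C(=O)NN=C(c2ccccn2)c2ccccn2)cc1`, 7640 nM
compound 3 `O=C(N/N=C/c1ccccn1)c1ccc(C(F)(F)F)cc1`, 22400 nM

In an ADME assay on cells (Homo sapiens) for antiproliferative activity, read by MTT assay (on this read-out lower numbers stand for stronger inhibition and higher numbers for weaker inhibition), compound 1 gives 1160 nM, compound 2 gives 7640 nM and compound 3 gives 22400 nM. Compound 2 therefore holds the second highest of the three numbers: compound 3 sits at a higher number, beyond the scatter, while compound 1 sits at a lower number, further away and also beyond the scatter.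

Compound 4 `O=C(NN=C(c1ccccn1)c1ccccn1)c1cccs1` has not yet been measured. Compared with compound 2 it differs in one place: thiophen-2-yl in place of 4-aminophenyl on a carbonyl carbon.

Within the data shown here, no pair of measured compounds shows this change, so no measured step can guide the expectation. Given the spread of the three numbers in this assay, a step of modest size is expected for compound 4, most likely towards a somewhat higher number or none beyond the scatter, as a 1.3-fold higher number from compound 2 to compound 4 (0.12 log units; within the scatter). Compound 4 is thus estimated at 10000 nM, with a range from 3000 nM to 35000 nM.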

Compound 4, half-maximal inhibitory concentration: 950 nM
The estimate for compound 4 lay 11-fold (1.02 log units) above the measured number; measured number outside the range, below it.
By their numbers in this assay, from the lowest: compounds 4 and 1 (each within the scatter of the next); then compound 2; then compound 3.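

In this assay, the substituent on this carbonyl carbon proves to matter: thiophen-2-yl in place of 4-aminophenyl gives an 8.0-fold lower number from compound 2 to compound 4 (0.91 log units; beyond the scatter). Among these compounds, the earlier compounds could not show this, since no two of them differed in only one place, so this is the first single change that can be read. The step combines the loss of the hydrogen-bond donor of 4-aminophenyl with a change from a six-membered aromatic ring of carbon only to a five-membered aromatic ring with 1 hetero atom, and no measurement at hand tells which of these counts.

The compounds shown include neither a plain phenyl nor a furan-2-yl on this carbonyl carbon, either of which could help separate these two differences. On these data alone, whether the same change has a similar effect on the cores of compound 1 and compound 3 also stays open.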